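Cyano Substitution on the Aryl Ring of Compound 3

This account rests on a few compounds, and the source may have more. Where it says the series, first, only, none or still open, it means among the compounds named here.

Compound 1 `COc1cc(-c2c(C)nn(-c3nc(-c4ccc(Cl)c(Cl)c4)c(SC(C)C)s3)c2C(=O)O)cc(C(F)(F)F)c1` and compound 2 `Cc1nn(-c2nc(-c3ccc(Cl)c(Cl)c3)c(SC(C)C)s2)c(C(=O)O)c1-c1ccc(C(F)(F)F)cc1` were tested in a functional assay on BJAB cells (Homo sapiens) for antiproliferative activity, with a stated time of 4 days; a higher number here means that more compound is needed for the effect, a lower number that less compound is needed. Compound 1 gives 1380 nM, while compound 2 gives 3500 nM, the highest of the two numbers. Compound 3 `Cc1nn(-c2nc(-c3ccc(Cl)c(Cl)c3)c(SC(C)C)s2)c(C(=O)O)c1-c1cc(C#N)cc(C(F)(F)F)c1` differs from compound 2 by 3-cyano-5-(trifluoromethyl)phenyl in place of 4-(trifluoromethyl)phenyl on an aromatic carbon. For the measured compounds named here, one measured step bears on this change: a 2.5-fold higher number from compound 1 to compound 2 (0.40 log units; beyond the scatter), where the ring with a single trifluoromethyl replaced a ring carrying two groups. Because a 2.5-fold higher number from compound 1 to compound 2 (0.40 log units; beyond the scatter) went in that direction, compound 3 is expected to show a modest step to a lower number, a 2.3-fold lower number from compound 2 to compound 3 (0.37 log units; beyond the scatter). Compound 3 is estimated at 1500 nM, with a range from 600 nM to 4000 nM.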

Compound 3, half-maximal effective concentration: 3600 nM
Estimate against measurement, compound 3: 2.4-fold (0.38 log units) below, within the range that was stated.
By their numbers in this assay, from the lowest: compound 1; then compounds 2 and 3 (each within the scatter of the next).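

In this assay, 3-cyano-5-(trifluoromethyl)phenyl in place of 4-(trifluoromethyl)phenyl leaves the number unchanged, with a 1.0-fold higher number from compound 2 to compound 3 (0.01 log units; within the scatter). Cyano in place of methoxy on the same ring does register, with a 2.6-fold higher number from compound 1 to compound 3 (0.42 log units; beyond the scatter), so among these compounds a further group on the ring does not by itself lower the number: methoxy goes with the lower number, while cyano does not. No measurement offered here accounts for this difference between methoxy and cyano.

The compounds shown leave open how an amine or a hydroxyl group would behave in that place on the ring. They also leave open whether methoxy would give the lower number with a chlorine in place of trifluoromethyl.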